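Amide variation on a shared aryl piperidine core

The compounds below may be only part of what the source reports. "The series", "measured", "known", "first", "only" and "open" are said of these compounds alone.

Compound 1 `Cc1cc(NC(=O)C2CC3CCC2C3)ccc1N1CCC(N2CCCC2C)C1` is tested in an assay on CHO cells for displacement of a labelled ligand from histamine receptor H3 (Macaca mulatta) (on this read-out higher numbers stand for weaker inhibition and lower numbers for stronger inhibition), and gives 130 nM. Within the three numbers in hand it stands highest. Compound 3 `Cc1cc(N2CCC(N3CCCC3C)C2)ccc1NC(=O)C1CC1` shares the core and carries a cyclopropyl amide; in this assay compound 3 gives 9.6 nM, a lower number than compound 1 by a margin well beyond the scatter. Compound 2 `Cc1cc(N2CC[C@H](N3CCC[C@@H]3C)C2)ccc1NC(=O)C1C(C)(C)C1(C)C` with its tetramethylcyclopropyl amide gives 0.55 nM in this assay, the lowest of the three, again far beyond the scatter from compound 1. Among the compounds with values here, no single-point step between measured compounds is available, so the comparisons above rest only on the values as they stand.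

Compound 4 `Cc1cc(NC(=O)C2CCOCC2)ccc1N1CCC(N2CCCC2C)C1` is the next variation at the same position. It differs from compound 1 as follows: a group of 6 heavy atoms (5 carbon, 1 oxygen; one six-membered non-aromatic ring with 1 hetero atom) in place of a group of 7 heavy atoms (7 carbon; 2 five-membered non-aromatic rings of carbon only), on a carbonyl carbon. The two measured amides with the smaller ring, compound 3 at 9.6 nM and compound 2 at 0.55 nM, both sit well below compound 1 at 130 nM, so a move away from the two five-membered rings is expected to lower the number. The step from compound 1 to compound 4 is therefore estimated to be a 4.3-fold lower number from compound 1 to compound 4 (0.64 log units; beyond the scatter), beyond the scatter and towards a lower number. Compound 4 is expected to give about 30 nM in this assay, within a range of 8 nM to 150 nM.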

Compound 4, inhibition constant: 17 nM
Beside the measured number, compound 4's estimate is 1.8-fold (0.25 log units) above it; the range from low to high includes it.
By their numbers in this assay, from the lowest: compound 2; then compounds 3 and 4 (each within the scatter of the next); then compound 1.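

Within the data shown here, this is the first step that can be read in one place: with the rest of compound 1 unchanged, oxan-4-yl in place of the group with two five-membered non-aromatic carbon rings, on the carbonyl carbon, gives a 7.6-fold lower number from compound 1 to compound 4 (0.88 log units; beyond the scatter) in this assay. The position therefore responds to the group on the carbonyl carbon alone, and a bulky all-carbon group is not needed here, since the entering ring, with its single oxygen and one hydrogen-bond acceptor, gives the lower number. The change alters ring count, ring size and hetero atom content together, and no measurement on hand separates these or accounts for the size of the step.

Still open, as far as these compounds go, is which part of the change carries the step: a cyclohexyl group on the same carbonyl carbon would keep the six-membered ring without the oxygen, and a piperidin-4-yl group would put a ring nitrogen where the oxygen stands. From the compounds shown here alone, how far the number moves with a smaller oxetan-3-yl ring or a longer open chain, such as a methoxyethyl group, also remains unknown on this core.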